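Fluorine pattern on the benzyl group: the next step

This account rests on a few compounds, and the source may have more. Where it says the series, first, only, none or still open, it means among the compounds named here.

Measured so far in an assay on FRT cells for positive allosteric modulation of Cystic fibrosis transmembrane conductance regulator variant N1303K (Homo sapiens), in the presence of a further agent that is not named here; a lower number here means that less compound is needed, a higher number that more compound is needed for the effect:
compound 1 `COc1ccc2[nH]c3c(c2c1)CCNC31CCN(Cc2ccccc2Cl)CC1`, 2200 nM
compound 2 `COc1ccc2[nH]c3c(c2c1)CCNC31CCN(Cc2cc(F)cc(F)c2)CC1`, 11100 nM
compound 3 `COc1ccc2[nH]c3c(c2c1)CCNC31CCN(Cc2cc(F)c(F)c(F)c2)CC1`, 2600 nM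

Compound 3 holds the second highest of the three numbers. Nearest is compound 1, the step of a 1.2-fold higher number from compound 1 to compound 3 (0.07 log units; within the scatter) lying within the scatter; furthest is compound 2, the step of a 4.3-fold lower number from compound 2 to compound 3 (0.63 log units; beyond the scatter) lying beyond it.

Compound 4 `COc1ccc2[nH]c3c(c2c1)CCNC31CCN(Cc2ccc(F)c(F)c2)CC1` differs from compound 3 by hydrogen in place of fluoro on an aromatic carbon. Within the data shown here, the one measured step on a single fluoro is a 4.3-fold lower number from compound 2 to compound 3 (0.63 log units; beyond the scatter), where a fluoro entered at another aromatic carbon and lowered the number. Removing a fluoro here is the reverse kind of change, at a different carbon, so a modest rise in this assay is expected, with wide uncertainty. Compound 4 is estimated at 4500 nM, range 1800 nM to 12000 nM, a step of a 1.7-fold higher number from compound 3 to compound 4 (0.24 log units; within the scatter).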

Compound 4, half-maximal effective concentration: 11000 nM
For compound 4 the middle estimate is 2.4-fold (0.39 log units) below the measured one, and the stated range covers the measured number.
By their numbers in this assay, from the lowest: compounds 1 and 3 (each within the scatter of the next); then compounds 4 and 2 (each within the scatter of the next).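

In this assay, the fluoro lost here carries weight, the change giving a 4.2-fold higher number from compound 3 to compound 4 (0.63 log units; beyond the scatter). The two difluorophenyl patterns cannot be told apart, with a 1.0-fold lower number from compound 2 to compound 4 (0.00 log units; within the scatter). Of the fluorinated benzyl groups shown, only the 3,4,5-trifluorophenyl group of compound 3 stays within the scatter of the 2-chlorophenyl group of compound 1, while the 3,4-difluorophenyl group gives a 5.0-fold higher number from compound 1 to compound 4 (0.70 log units; beyond the scatter).

No supporting data explain these steps. From the compounds shown here alone, whether a nitrile or trifluoromethyl group at the same aromatic carbon could replace this fluoro remains open.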